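From Fluoro to Nitro at an Assay Limit

The source may report more compounds than this note shows. Statements on the series, on what has been measured and on what is new or still open speak of the compounds shown alone.

Three related compounds have been tested in a functional assay on HT-29 cells (Homo sapiens) for inhibition, read by sulforhodamine B assay, with a stated time of 48 h (on this read-out higher numbers stand for weaker inhibition of growth and lower numbers for stronger inhibition of growth), so far. Compound 1 `CCOC(=O)c1nn(-c2ccccc2)c(-c2ccc(OC)cc2)c1CNC(C)(C)C` gives real numbers, and compound 1 reads 61300 nM; 44200 nM (2 entries) in this test. Compound 2 `CCOC(=O)c1nn(-c2ccc(Cl)cc2)c(-c2ccc(Br)cc2)c1CNC(C)(C)C` gives no real number: its entries of > 511000 nM; > 476000 nM (2 entries) are limits of the assay.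

Compound 3 `CC(C)(C)NCc1c(C(=O)O)nn(-c2ccccc2)c1-c1ccc(F)cc1` also stands only at a limit of the assay, > 680000 nM in the one entry that shows a figure, and two further entries for compound 3 hold no single number.

Compound 4 `CC(C)(C)NCc1c(C(=O)O)nn(-c2ccccc2)c1-c1ccc([N+](=O)[O-])cc1` differs from compound 3 in one place, on an aromatic carbon para to a large group. There, nitro stands in place of fluoro, turning 4-fluorophenyl into 4-nitrophenyl nitro in place of fluoro on an aromatic carbon in the structure. Within the data shown here, no measured pair shows what a single change of this kind does in this assay.

The nearest guide is compound 3, whose limit of > 680000 nM suggests that no step beyond the usual scatter should be expected, and no clear direction either. The estimated step is an at least 1.1-fold lower number from compound 3 to compound 4 (0.05 log units; that floor lies within the scatter) and so stays small. Compound 4 may well return only a limit too. If a number does appear, compound 4 is expected at 600000 nM within an estimated range of 200000 nM to 1000000 nM in this test.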

Compound 4, concentration for 50% growth inhibition: > 634000 nM
Compound 4: a limit, no number (the forecaster's own chance of this, stated with the estimate: 75%); middle value at least 1.0-fold (0.02 log units) away from the limit.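

In this assay compound 4 gives only a limit of > 634000 nM and no real number. Compound 3 also gives only a limit of > 680000 nM and so no step can be read between compound 3 and compound 4. The compounds shown leave open whether nitro in place of fluoro changes growth inhibition at all, and in which direction.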